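Butoxy for hexylsulfanyl: cytotoxicity still at the ceiling

This account rests on a few compounds, and the source may have more. Where it says the series, first, only, none or still open, it means among the compounds named here.

Three compounds built on one shared core have been examined in an ADME assay on BCBL1 cells (Homo sapiens) for cytotoxicity, with a stated time of 7 days; a lower number here means that less compound is tolerated, a higher number that more compound is tolerated. Compound 1 `CC(C)CSc1nc(N)nc2c1ncn2/C=C1/CC1(CO)CO` gives > 20000 nM, which is a limit of the assay rather than a number. Compound 2 `CCCNc1nc(N)nc2c1ncn2/C=C1/CC1(CO)CO` gives > 20000 nM, again a limit. Compound 3 `CCCCCCSc1nc(N)nc2c1ncn2/C=C1/CC1(CO)CO` gives > 20000 nM, also a limit. Because (the limit of > 20000 nM in this assay, at which 3 of the 3 values shown sit), none of the steps between these compounds can be read: a step that the two limits leave unreadable from compound 1 to compound 2, a step that the two limits leave unreadable from compound 1 to compound 3 and a step that the two limits leave unreadable from compound 2 to compound 3 all stay hidden behind the same ceiling. Compound 3 therefore stands exactly where the other two measured compounds stand, at the limit, with no number to set it apart from them.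

Compound 4 `CCCCOc1nc(N)nc2c1ncn2/C=C1/CC1(CO)CO` is the next compound, and it differs from compound 3 by butoxy in place of hexylsulfanyl on an aromatic carbon. The measured steps that bear on this change are the two that also exchange the group on that aromatic carbon, a step that the two limits leave unreadable from compound 1 to compound 2 and a step that the two limits leave unreadable from compound 2 to compound 3, and both are unreadable because of the limit of > 20000 nM in this assay, at which 3 of the 3 values shown sit. Among the measured compounds shown here, no measured step thus supplies a size or a direction; the expectation is simply that compound 4 will remain at or near the same ceiling in this assay. Compound 4 is accordingly estimated at 20000 nM, from 10000 nM to 40000 nM. The step expected from compound 3 to compound 4 is a number no higher from compound 3 to compound 4 (the limit leaves the size open), that is, nothing beyond the scatter.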

Compound 4, half-maximal cytotoxic concentration: > 20000 nM
Compound 4 ended at the assay's limit (the forecaster's own chance of this, stated with the estimate: 85%); the middle value sits exactly at the limit.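

The steps linking compound 4 to compound 1, compound 2 and compound 3 in this assay cannot be read, because each of the four values is a limit and not a number: the limit of > 20000 nM in this assay, at which 4 of the 4 values shown sit. The compounds shown leave open whether butoxy, propylamino, isobutylsulfanyl and hexylsulfanyl differ at all in how much compound is tolerated.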